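Fluorine added to the aryl ether of a spirocyclic agonist

A few compounds are considered here, and "the series" means these few. Any claim that something is new, unique, unknown or untested is made for them only; others in the source may bear on it.

Measured so far:
compound 1, `CC(C)(C)OC(=O)N1CCC2(CC1)CC(CCCOc1ccc(S(C)(=O)=O)cc1F)C2`, 25 nM
compound 2, `CCc1cnc(N2CCC3(CC2)CC(CCCOc2ccc(S(C)(=O)=O)cc2)C3)nc1`, 31 nM

Of the compounds shown here, two have been tested in a functional assay on cells for agonist activity at Glucose-dependent insulinotropic receptor (Homo sapiens), read by HTRF and cAMP accumulation, with a stated time of 30 min; a lower number here means that less compound is needed, a higher number that more compound is needed for the effect. Compound 1 carries a carbamate group on the shared core and gives 25 nM. Compound 2 carries an ethyl-substituted pyrimidine group instead and gives 31 nM. Compound 2 has the higher of the two numbers, but the gap to compound 1 is within the usual scatter of repeated measurements, so the two values show no real difference between them.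

Compound 3, `CCc1cnc(N2CCC3(CC2)CC(CCCOc2ccc(S(C)(=O)=O)cc2F)C3)nc1`, has not yet been measured. Within the data shown here, its only change from compound 2 is fluoro in place of hydrogen on an aromatic carbon, a fluoro in place of hydrogen on an aromatic carbon. Among the measured compounds shown here, no measured pair in this set isolates that single change, so there is no directly comparable step to lean on. Given the small size of the change and the near-equal values of compound 1 and compound 2, compound 3 is expected to land close to compound 2, with a step of a 1.2-fold lower number from compound 2 to compound 3 (0.09 log units; within the scatter) that stays within the scatter. The estimate for compound 3 in this assay is 25 nM, within a range of 10 nM to 65 nM.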

Compound 3, half-maximal effective concentration: 225 nM
Compound 3: middle estimate off by 9.0-fold (0.95 log units), on the low side; the whole stated range lies below it.
By their numbers in this assay, from the lowest: compounds 1 and 2 (each within the scatter of the next); then compound 3.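

In this assay, the smallest possible addition, one fluoro in place of hydrogen on an aromatic carbon that is ortho to a large group and meta to a methylsulfonyl group, gives a 7.3-fold higher number from compound 2 to compound 3 (0.86 log units; beyond the scatter), so this position is sensitive to the change when 5-ethylpyrimidin-2-yl sits on the ring nitrogen. With the fluoro present in both compounds, 5-ethylpyrimidin-2-yl in place of tert-butoxycarbonyl on that nitrogen gives a 9.0-fold higher number from compound 1 to compound 3 (0.95 log units; beyond the scatter), which shows that the group at the other end of the molecule also matters strongly in the fluorinated series. Nothing available here explains why either step is so large.

Whether the fluoro would cost as much with tert-butoxycarbonyl on the nitrogen stays open, as the compounds shown hold no partner for compound 1 that differs from it only by that fluoro. Going by these compounds, it also stays open whether the sensitivity belongs to fluoro alone or to any group on this carbon, such as a chloro, methyl or methoxy group.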